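Anilide versus benzylamide on the amide nitrogen

This account rests on a few compounds, and the source may have more. Where it says the series, first, only, none or still open, it means among the compounds named here.

Compound 1 `COc1ccc2c(=O)c(/C=C/C(=O)Nc3cccc(Cl)c3)coc2c1` carries a 3-chlorophenyl on the amide-type nitrogen, and in a functional assay on HeLa cells (Homo sapiens) for inhibition, read by MTT assay, with a stated time of 48 h (a lower number here means a stronger inhibitor, a higher number a weaker inhibitor), compound 1 gives 11900 nM. Compound 2 `COc1ccc2c(=O)c(/C=C/C(=O)NCc3ccc(C)cc3)coc2c1` carries a 4-methylbenzyl at that nitrogen. In this assay compound 2 gives only > 100000 nM, which is a limit of the assay and not a number. Compound 2 therefore stands at the limit of > 100000 nM in this assay, at which 1 of the 2 values shown sits, and it is the weaker of the two measured compounds, with an at least 8.4-fold higher number from compound 1 to compound 2 (0.92 log units; beyond the scatter).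

Compound 3 `COc1ccc2c(=O)c(/C=C/C(=O)Nc3ccc(C)cc3)coc2c1` differs from compound 2 by 4-methylphenyl in place of 4-methylbenzyl on an amide-type nitrogen. Going by the values given here, the only measured step that bears on this change is the one from compound 1 to compound 2, which joins a change of the ring substituent to the change from a phenyl to a benzyl attachment and cannot be split between the two. Compound 3 returns the amide to the aryl-linked form, so the expected step is a lower number, at least modest, given as an at least 6.6-fold lower number from compound 2 to compound 3 (0.82 log units; beyond the scatter). For compound 3 the estimate is 15000 nM, with a range from 4000 nM to 60000 nM; a limit remains possible.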

Compound 3, half-maximal inhibitory concentration: 24100 nM
Compound 3: the middle estimate sits 1.6-fold (0.21 log units) below what was measured; the measured number falls inside the stated range.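

With the methyl-bearing ring kept, the change of 4-methylbenzyl to 4-methylphenyl on the amide-type nitrogen gives an at least 4.1-fold lower number from compound 2 to compound 3 (0.61 log units; beyond the scatter) in this assay, so the attachment of the ring to that nitrogen matters on its own, which the earlier step could not show because it also changed the ring substituent. Compound 2 stands at a limit of the assay and not at a number, so this step fixes only the smallest possible size of the change: the limit of > 100000 nM in this assay, at which 1 of the 3 values shown sits.

The two aryl-linked amides add a second, separate reading, with 4-methylphenyl in place of 3-chlorophenyl giving a 2.0-fold higher number from compound 1 to compound 3 (0.31 log units; beyond the scatter), so the substituent on the aryl ring also moves the number, though this step is modest.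

The compounds shown leave open whether that modest step comes from the identity of the substituent or from where it sits on the ring, since the 3-chlorophenyl and the 4-methylphenyl differ in both. An unsubstituted phenyl on the same nitrogen would give a reference for both substituents, and a 3-chlorobenzyl or a longer chain such as phenethyl would test whether the loss on moving away from the aryl-linked form holds beyond a single pair.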